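A few compounds are considered here, and "the series" means these few. Any claim that something is new, unique, unknown or untested is made for them only; others in the source may bear on it.

In an ADME assay on BJ cells (Homo sapiens) for cytotoxicity, with a stated time of 72 h (a lower number here means that less compound is needed, a higher number that more compound is needed for the effect), compound 2 `Cc1cc(NC(=O)Nc2ccccc2C(F)(F)F)c2ccccc2n1` gives > 25000 nM which is a limit of the assay and not a number. Compound 1 `COc1ccccc1NC(=O)Nc1cc(C)nc2ccccc12` gives > 25000 nM and this too is a limit. The data so far show the limit of > 25000 nM in this assay, at which 2 of the 2 values shown sit, and so give no exact position for compound 2.

The next structure is compound 3 `Cc1cc(NC(=O)Nc2ccccc2F)c2ccccc2n1` in which fluoro takes the place of trifluoromethyl on an aromatic carbon, ortho to a large group (fluoro in place of trifluoromethyl on an aromatic carbon). Going by the values given here, only one measured step bears on this change, as it swaps a group at the same place. That step is a step that the two limits leave unreadable from compound 1 to compound 2 and it offers no size to carry forward. Neither compound 1 nor compound 2 has left the limit, so compound 3 is expected to stay at or close to it. The estimated step is a number no higher from compound 2 to compound 3 (the limit leaves the size open) and no change beyond the usual scatter is expected in this assay for this swap. For compound 3 the estimated value is 25000 nM with an expected range from 10000 nM to 50000 nM and a limit is the likeliest outcome.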

Compound 3, half-maximal effective concentration: > 25000 nM
Compound 3 was reported as a limit; the forecaster's own chance of this, stated with the estimate: 85%; the middle value sits exactly at the limit.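

In this assay compound 3 gives > 25000 nM, which is a limit of the assay and not a number. No step among compound 1, compound 2 and compound 3 can be read, for one reason: the limit of > 25000 nM in this assay, at which 3 of the 3 values shown sit. These compounds leave open at what concentration an effect on the cells would appear, and whether swapping this group changes that concentration.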